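Ring-opening step from compound 3 to compound 4

The source may hold more compounds than are shown below. What is called first, only, known or untested is meant among the compounds shown, and "the series" means these compounds.

Measured so far in a functional assay on SW480 cells (Homo sapiens) for cytotoxicity, read by MTT assay, with a stated time of 48 h; a higher number here means a weaker inhibitor, a lower number a stronger inhibitor:
- compound 1 `C=CC(=C)CC[C@@H]1[C@@]2(C)CCC[C@](C)(COC(=O)/C=C/c3ccc(O)cc3)[C@@H]2CC[C@@]1(C)O`: 19300 nM
- compound 2 `C=C1CC[C@@H]2[C@](C)(CCC[C@]2(C)C(=O)O)[C@H]1CC/C(C)=C/CO`: a limit of this assay, > 40000 nM
- compound 3 `C=C[C@@]1(C)O[C@H]1C[C@H]1C(=C)CC[C@@H]2[C@]1(C)CCC[C@]2(C)C(=O)O`: a limit of this assay, > 40000 nM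

Compound 3 stands at the limit of this assay, and it is not alone there: the limit of > 40000 nM in this assay, at which 2 of the 3 values shown sit. Going by the values given here, only compound 1 gives a real number, and no step connects compound 1 to compound 3 in a single change. Among the compounds with values here, the one measured step, from compound 2 to compound 3, is a step that the two limits leave unreadable from compound 2 to compound 3, so it gives no size to work from.

Compound 4 `C=C[C@@](C)(O)CC[C@H]1C(=C)CC[C@@H]2[C@]1(C)CCC[C@]2(C)C(=O)O` is the open-chain counterpart of compound 3: a group of 6 heavy atoms (5 carbon, 1 oxygen; no ring) in place of a group of 6 heavy atoms (5 carbon, 1 oxygen; one three-membered non-aromatic ring with 1 hetero atom), on a saturated chain carbon bound to a saturated ring carbon. This change is the reverse, in kind, of the change that distinguishes compound 2 from compound 3, and that step carried no readable size.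

With both neighbours at the limit and no readable step, the expectation for compound 4 in this assay is that it stays weak, and the step of an at least 1.1-fold lower number from compound 3 to compound 4 (0.05 log units; that floor lies within the scatter) is taken as within the scatter. Compound 4 is therefore estimated at 35000 nM, with a range from 12000 nM to 90000 nM, and a real chance that only a limit is again reported.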

Compound 4, half-maximal inhibitory concentration: > 40000 nM
Compound 4 ended at the assay's limit; the forecaster's own chance of this, stated with the estimate: 60%; middle value at least 1.1-fold (0.05 log units) away from the limit.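

Compound 4 reads only as a limit in this assay, like compound 2 and compound 3, so none of the steps among these three compounds can be read: the limit of > 40000 nM in this assay, at which 3 of the 4 values shown sit.

The compounds shown leave open how far compound 2, compound 3 and compound 4 actually lie from one another in this assay, and whether swapping these groups changes cytotoxicity at all.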